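This account rests on a few compounds, and the source may have more. Where it says the series, first, only, none or still open, it means among the compounds named here.

Compound 1 `COc1ccccc1-n1cc(CN2C(=O)C[C@@H]3CC[C@@]2(C)C3(C)C)nn1` gives 110 nM in a functional assay on HepG2 cells (Homo sapiens) for inhibition, read by MTT assay, with a stated time of 24 h; on this read-out higher numbers stand for weaker inhibition and lower numbers for stronger inhibition.
Compound 2 `CC1(C)[C@H]2CC[C@]1(C)N(Cc1cn(-c3ccccc3Br)nn1)C(=O)C2` gives 150 nM in this assay.
Compound 3 `CC1(C)[C@H]2CC[C@]1(C)N(Cc1cn(-c3cccc(Br)c3)nn1)C(=O)C2` gives 20 nM in this assay.

All three compounds share the same core and differ only in the aryl group on an aromatic nitrogen. Compound 3 stands lowest of the three in this assay, and since its steps to compound 1 and to compound 2 both lie beyond the scatter, it is the strongest inhibitor on the numbers shown.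

Compound 4 `CC1(C)[C@H]2CC[C@]1(C)N(Cc1cn(-c3ccccc3Cl)nn1)C(=O)C2` is the next step: 2-chlorophenyl in place of 3-bromophenyl on an aromatic nitrogen. For the measured compounds named here, two measured steps bear on it. Moving the bromine round the ring gave a 7.5-fold lower number from compound 2 to compound 3 (0.88 log units; beyond the scatter), so the reverse placement is expected to cost potency. Exchanging one substituent for another in the same position gave a 1.4-fold higher number from compound 1 to compound 2 (0.13 log units; within the scatter), which suggests that swapping bromine for chlorine matters little. Compound 4 therefore resembles compound 2 more than compound 3, and a higher number is expected, roughly a 6.0-fold higher number from compound 3 to compound 4 (0.78 log units; beyond the scatter). Compound 4 is estimated at 120 nM, in a range from 40 nM to 350 nM.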

Compound 4, half-maximal inhibitory concentration: 60 nM
For compound 4 the middle estimate is 2.0-fold (0.30 log units) above the measured one; low and high end bracket the measured number.
By their numbers in this assay, from the lowest: compound 3; then compounds 4, 1 and 2 (each within the scatter of the next, the first and the last beyond it).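

With the substituent kept on the same aromatic carbon, chloro in place of bromo gives a 2.5-fold lower number from compound 2 to compound 4 (0.40 log units; beyond the scatter) and so the choice of halogen counts here, which the earlier swap of bromo for methoxy with a 1.4-fold higher number from compound 1 to compound 2 (0.13 log units; within the scatter) had not suggested. Chloro in place of methoxy gives a 1.8-fold lower number from compound 1 to compound 4 (0.26 log units; within the scatter) and so this read-out does not separate those two groups. Compound 3 still holds the lowest number, but a 3.0-fold higher number from compound 3 to compound 4 (0.48 log units; beyond the scatter) changes the halogen and its place on the ring together, so this step alone cannot assign the difference to either change.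

The compounds shown leave open how a 3-chlorophenyl group would compare, which would separate halogen from placement, and how an amine or a carboxylic acid on the phenyl ring would behave. Nothing given here explains why these numbers differ.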